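The source may hold more compounds than are shown below. What is called first, only, known or untested is meant among the compounds shown, and "the series" means these compounds.

In an assay on CHO cells for activation of soluble guanylate cyclase alpha1/beta1 complex (Homo sapiens), read by cGMP accumulation (on this read-out higher numbers stand for an effect only at larger amounts of compound and lower numbers for an effect already at smaller amounts), compound 2 `COC(=O)N(C)c1c(N)nc(-n2nc(Cc3c(F)ccc(F)c3F)c3ccccc32)nc1N` gives 270 nM, the lowest of the three numbers recorded. Compound 3 `COC(=O)N(C)c1c(N)nc(-n2nc(Cc3c(F)ccc(F)c3F)c3cc(Cl)ccc32)nc1N` gives 700 nM in this assay, and compound 1 `COC(=O)N(C)c1c(N)nc(-n2nc(Cc3ccccc3F)c3cc(F)ccc32)nc1N` gives 960 nM. Within the data shown here, the only single-point step among them is a 2.6-fold higher number from compound 2 to compound 3 (0.41 log units; beyond the scatter), a chloro in place of hydrogen on an aromatic carbon. Compound 4 `COC(=O)N(C)c1c(N)nc(-n2nc(Cc3ccccc3F)c3ccccc32)nc1N` differs from compound 2 by 2-fluorophenyl in place of 2,3,6-trifluorophenyl on a saturated chain carbon bound to an aromatic carbon. Among the measured compounds shown here, no measured step matches this change; compound 1 carries the same 2-fluorobenzyl group but is not otherwise identical to compound 4, so its value and that of compound 2 show only that the two differ. Compound 4 is therefore expected to sit near compound 2 or somewhat above it, a step of a 1.5-fold higher number from compound 2 to compound 4 (0.17 log units; within the scatter). The estimate for compound 4 is 400 nM, with a range from 150 nM to 1100 nM.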

Compound 4, half-maximal effective concentration: 310 nM
Estimate against measurement, compound 4: 1.3-fold (0.11 log units) above; measured number inside the range.
By their numbers in this assay, from the lowest: compounds 2 and 4 (each within the scatter of the next); then compounds 3 and 1 (each within the scatter of the next).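

In this assay, the change from 2,3,6-trifluorobenzyl to 2-fluorobenzyl gives a 1.1-fold higher number from compound 2 to compound 4 (0.06 log units; within the scatter), so this place on the saturated chain carbon tolerates the loss of those fluoro groups with the core otherwise bare. The core substituent does register: hydrogen in place of fluoro on an aromatic carbon gives a 3.1-fold lower number from compound 1 to compound 4 (0.49 log units; beyond the scatter), the same direction as a 2.6-fold higher number from compound 2 to compound 3 (0.41 log units; beyond the scatter). Nothing on hand explains either step. From the compounds shown here alone, whether the benzyl change stays this small with a halogen on the core remains open. So does how a plain benzyl, a methoxy group on the ring or an amine would read at this place.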